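This account rests on a few compounds, and the source may have more. Where it says the series, first, only, none or still open, it means among the compounds named here.

Working notes on the series in a functional assay on MCF7 cells (Homo sapiens) for inhibition, read by sulforhodamine B assay; on this read-out lower numbers stand for stronger inhibition and higher numbers for weaker inhibition. Compound 1 `O=C1C=C(NC2CCCCC2)C(=O)c2c1nc1n2[C@H]2OC[C@@H](O)[C@H]2OC1` returns only a limit, > 8000 nM. Compound 2 `O=C1C(N2CCCCC2)=CC(=O)c2c1nc1n2[C@H]2OC[C@@H](O)[C@H]2OC1` likewise returns only a limit, > 8000 nM. Compound 3 `O=C1C(NC2CC2)=CC(=O)c2c1nc1n2[C@H]2OC[C@@H](O)[C@H]2OC1` also returns only a limit, > 16000 nM. Compound 1 therefore cannot be ranked: every value shown is a limit, two of them at the limit of > 8000 nM in this assay, at which 2 of the 3 values shown sit, and one at the limit of > 16000 nM in this assay, at which 1 of the 3 values shown sits. Among the compounds with values here, the only single-site step with both ends measured, a step that the two limits leave unreadable from compound 2 to compound 3, is itself not readable, so no measured step supplies a size for anything in this set.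

Compound 4 `O=C1C=C(N2CCCCC2)C(=O)c2c1nc1n2[C@H]2OC[C@@H](O)[C@H]2OC1` is the next candidate; it differs from compound 1 by piperidin-1-yl in place of cyclohexylamino on a double-bonded ring carbon. Within the data shown here, no measured step bears on this change. Compound 2 also carries a piperidin-1-yl group and sits at a limit, which gives no ground to expect a numerical reading for compound 4. The step is expected to be a step that the limit leaves unreadable from compound 1 to compound 4, meaning nothing beyond a limit. Compound 4 is estimated at 20000 nM, within 8000 nM to 60000 nM, most likely reported again as a limit.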

Compound 4, half-maximal inhibitory concentration: > 8000 nM
Compound 4: a limit, no number (the forecaster's own chance of this, stated with the estimate: 85%); the middle value lies beyond the limit too.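

The step from compound 1 to compound 4 cannot be read, as both compounds return only a limit in this assay: the limit of > 8000 nM in this assay, at which 3 of the 4 values shown sit.

The compounds shown leave open how piperidin-1-yl and cyclohexylamino compare at this place, and whether any of these compounds gives a numerical value in this assay.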